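The compounds below may be only part of what the source reports. "The series", "measured", "known", "first", "only" and "open" are said of these compounds alone.

In an ADME assay on microsomes from liver (Mus musculus) for metabolic stability (a higher number here means faster removal of the compound, a lower number slower removal), compound 1 (`Cc1n[nH]c(-c2ncc3cccnc3c2O)n1`) gives 3.3 mL.min-1.g-1. Compound 2 (`Cc1n[nH]c(-c2ncc3c(N4CCCC4=O)ccnc3c2O)n1`) gives < 0.5 mL.min-1.g-1, which is a limit of the assay and not a number. Compound 2 therefore stands at the limit of < 0.5 mL.min-1.g-1 in this assay, at which 1 of the 2 values shown sits, and no exact value is available for it.

Compound 3 (`Cc1n[nH]c(-c2ncc3c(N4CCCCS4(=O)=O)ccnc3c2O)n1`) differs from compound 2 at one place, on an aromatic carbon opposite the ring nitrogen: a group of 8 heavy atoms (4 carbon, 1 nitrogen, 2 oxygen, 1 sulfur; one six-membered non-aromatic ring with 2 hetero atoms) in place of a group of 6 heavy atoms (4 carbon, 1 nitrogen, 1 oxygen; one five-membered non-aromatic ring with 1 hetero atom), on an aromatic carbon.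

Among the measured compounds shown here, one measured step bears on this change, an at least 6.6-fold lower number from compound 1 to compound 2 (0.81 log units; beyond the scatter), where 2-oxopyrrolidin-1-yl takes the place of hydrogen at that carbon. For the measured compounds named here, no measured step covers the exchange of one ring group for the other. Compound 3 is thus expected to stay close to compound 2 rather than return towards compound 1, with a reading at the limit still possible. The expected step is small and upward, within the scatter: an at least 1.2-fold higher number from compound 2 to compound 3 (0.07 log units; that floor lies within the scatter). In this assay compound 3 is estimated at 0.6 mL.min-1.g-1, with an expected range of 0.3 mL.min-1.g-1 to 1.6 mL.min-1.g-1.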

Compound 3, intrinsic clearance in microsomes: 0.6 mL.min-1.g-1
Compound 3: the middle estimate sits on the measured number at the digits printed; low and high end bracket the measured number.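

In this assay, the lower number at the aromatic carbon opposite the ring nitrogen is not tied to 2-oxopyrrolidin-1-yl alone, since the six-membered ring group with 2 hetero atoms also gives a 5.5-fold lower number from compound 1 to compound 3 (0.74 log units; beyond the scatter). Exchanging one ring group for the other gives an at least 1.2-fold higher number from compound 2 to compound 3 (0.07 log units; that floor lies within the scatter), so no real difference between the two ring groups can be claimed. Compound 2 carries a limit of the assay and not a number, so the true size of that exchange stays unfixed: the limit of < 0.5 mL.min-1.g-1 in this assay, at which 1 of the 3 values shown sits.

As far as these compounds go, both groups at this carbon are non-aromatic rings, so it remains open whether an open-chain dimethylamino group or a small methoxy group would bring the same drop from the core of compound 1. Also open, from the compounds shown here alone, is whether a morpholine ring would stay in the same range.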